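This account rests on a few compounds, and the source may have more. Where it says the series, first, only, none or still open, it means among the compounds named here.

Measured in a functional assay on MCF7 cells (Homo sapiens) for antiproliferative activity, read by MTT assay, with a stated time of 72 h; a higher number here means a weaker inhibitor, a lower number a stronger inhibitor:
- compound 1 `C#CCSc1nc(Sc2nnnn2CCN(C)C)c(C#N)c(-c2ccc(Cl)cc2)n1`: 6180 nM
- compound 2 `C#CCSc1nc(Sc2ccccn2)c(C#N)c(-c2cc(OC)c(OC)c(OC)c2)n1`: > 10000 nM (a limit, not a number)
- compound 3 `C=CC(=O)Nc1ccccc1CN(C(=O)Nc1cccc(C(F)(F)F)c1)C1CCN(C(C)CCC)CC1`: 10200 nM

Compound 2 stands at the limit of > 10000 nM in this assay, at which 1 of the 3 values shown sits. Its entry is a limit and gives no number to measure a step from. The values of compound 1 6180 nM and compound 3 10200 nM lie within the usual scatter of each other. Compound 3 does not share the core of compound 1, and it adds little to the question here.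

Compound 4 `C#CCSc1nc(Sc2nc[nH]n2)c(C#N)c(-c2cc(OC)c(OC)c(OC)c2)n1` has not yet been measured. It keeps the core of compound 2 and changes one group: 1H-1,2,4-triazol-3-yl in place of pyridin-2-yl on a sulfur. A five-membered aromatic ring thus takes the place of a six-membered one on the sulfur.

For the measured compounds named here, no measured pair covers this change. Going by the values given here, the expectation rests on compound 1 at 6180 nM, the one compound with a number that shares the core of compound 2, although it differs from compound 2 in more than one place. In this assay the expected step of an at least 1.1-fold lower number from compound 2 to compound 4 (0.04 log units; that floor lies within the scatter) is none beyond the scatter, with no firm direction. A second result reported only as a limit is also quite possible. For compound 4 the estimated value is 9000 nM, with an expected range of 2500 nM to 30000 nM.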

Compound 4, half-maximal inhibitory concentration: > 20000 nM
Compound 4: a limit, no number; the forecaster's own chance of this, stated with the estimate: 50%; middle value at least 2.2-fold (0.34 log units) away from the limit.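

In this assay compound 2 and compound 4 are both reported only as limits, and no step can be read between them. The limit for compound 2 is > 10000 nM. The limit for compound 4 is > 20000 nM. Left open is whether 1H-1,2,4-triazol-3-yl in place of pyridin-2-yl on a sulfur changes the value at all.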